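The compounds below may be only part of what the source reports. "The series", "measured", "known", "first", "only" and "open" are said of these compounds alone.

Measured so far in a functional assay (aorta) for inhibition, with Homo sapiens as the target, using microsomes, in the presence of a further agent that is not named here (on this read-out higher numbers stand for weaker inhibition and lower numbers for stronger inhibition), are these compounds
- Compound 1 `CCOC(=O)/C(C)=C\c1ccc(Cc2cccnc2)n1C(C)C` with 32000 nM
- Compound 2 `C/C(=C\c1ccc(Cn2ccnc2)[nH]1)C(=O)OCc1ccccc1` with 20000 nM
- Compound 3 `CCOC(=O)/C(C)=C\c1ccc(Cc2cccnc2)n1-c1ccccc1` with 180000 nM

Compound 3 has the highest number of the three, and its distance from each of the other two lies beyond the scatter. Compound 4 `CCOC(=O)/C(C)=C\c1ccc(Cc2cccnc2)n1CC(C)(C)C` has not yet been measured. It differs from compound 3 by neopentyl in place of phenyl on an aromatic nitrogen in the form of neopentyl in place of phenyl on an aromatic nitrogen.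

Within the data shown here, one measured step bears on this change: a 5.6-fold higher number from compound 1 to compound 3 (0.75 log units; beyond the scatter) for phenyl in place of isopropyl on an aromatic nitrogen. That step is modest. The step to compound 4 runs the other way, from phenyl back to a group without a ring. Among the measured compounds shown here, compound 1, with isopropyl, gives 32000 nM and is the closest guide, although no measured compound carries neopentyl. A modest step of similar size towards a lower number is therefore expected in this assay.

The estimated step is a 4.5-fold lower number from compound 3 to compound 4 (0.65 log units; beyond the scatter) and remains uncertain. Compound 4 is expected at 40000 nM in a range from 12000 nM to 130000 nM by this estimate.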

Compound 4, half-maximal inhibitory concentration: 57000 nM
The estimate for compound 4 lay 1.4-fold (0.15 log units) below the measured number, and the stated range covers the measured number.
By their numbers in this assay, from the lowest: compounds 2, 1 and 4 (each within the scatter of the next, the first and the last beyond it); then compound 3.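

In this assay, neopentyl in place of phenyl on the aromatic nitrogen gives a 3.2-fold lower number from compound 3 to compound 4 (0.50 log units; beyond the scatter) and so adds a second group without a ring, after isopropyl, that stands apart from phenyl at this position. Between those two ringless groups, the change gives a 1.8-fold higher number from compound 1 to compound 4 (0.25 log units; within the scatter) and therefore shows no difference that can be told from the scatter, even though neopentyl is the larger group by name. No measurement at hand accounts for either step.

The compounds shown leave open whether a smaller group such as methyl, a longer straight chain such as n-butyl, or a chain ending in an amine or a carboxylic acid would stay level with isopropyl and neopentyl on this nitrogen. They also leave open whether a benzyl group would follow phenyl or the ringless groups.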